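Fluoro for hydrogen on the benzyl rings: cytotoxicity notes

A few compounds are considered here, and "the series" means these few. Any claim that something is new, unique, unknown or untested is made for them only; others in the source may bear on it.

Measured compounds:
compound 1 `CC(C)(C)OC(=O)N[C@@H](CC(N)=O)C(=O)N(Cc1ccc(F)cc1)C1(C(=O)NCc2ccccc2)CCN(Cc2ccccc2)CC1`: > 100000 nM
compound 2 `CC(C)(C)OC(=O)N[C@@H](CC(N)=O)C(=O)N(Cc1ccccc1)C1(C(=O)NCc2ccccc2)CCN(Cc2ccccc2)CC1`: > 100000 nM
compound 3 `COC(=O)C[C@H](NC(=O)OC(C)(C)C)C(=O)N(Cc1ccc(F)cc1)C1(C(=O)NCc2ccccc2)CCN(Cc2cccc(F)c2)CC1`: 84000 nM

Compound 2 `CC(C)(C)OC(=O)N[C@@H](CC(N)=O)C(=O)N(Cc1ccccc1)C1(C(=O)NCc2ccccc2)CCN(Cc2ccccc2)CC1` is the parent without fluorine on either benzyl ring. In an ADME assay on MDCK cells (Canis lupus familiaris) for cytotoxicity, read by microscopy, with a stated time of 72 h (a lower number here means that less compound is tolerated, a higher number that more compound is tolerated), compound 2 returns a limit, > 100000 nM, and no number. Compound 1 `CC(C)(C)OC(=O)N[C@@H](CC(N)=O)C(=O)N(Cc1ccc(F)cc1)C1(C(=O)NCc2ccccc2)CCN(Cc2ccccc2)CC1` carries the change (fluoro in place of hydrogen on an aromatic carbon). In this assay compound 1 also returns only a limit, > 100000 nM. The step from compound 2 to compound 1 is therefore a step that the two limits leave unreadable from compound 2 to compound 1; both values sit at the limit of > 100000 nM in this assay, at which 2 of the 3 values shown sit, so the size of this step cannot be read.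

Compound 3 `COC(=O)C[C@H](NC(=O)OC(C)(C)C)C(=O)N(Cc1ccc(F)cc1)C1(C(=O)NCc2ccccc2)CCN(Cc2cccc(F)c2)CC1` differs from compound 2 in more than one place, and the difference between the two cores is not broken down here. In this assay compound 3 is the only one of the three to give a number, 84000 nM.

Compound 4 `COC(=O)C[C@H](NC(=O)OC(C)(C)C)C(=O)N(Cc1ccc(F)cc1)C1(C(=O)NCc2ccccc2)CCN(Cc2cc(F)cc(F)c2)CC1` is not yet measured. It differs from compound 3 by fluoro in place of hydrogen on an aromatic carbon. Within the data shown here, this is the same kind of change as the one from compound 2 to compound 1, not the same: there the fluorine enters para to a large group, here it enters meta to a fluoro group and meta to a large group. That earlier step gave no readable size, so the expectation for compound 4 rests on compound 3 alone, with its value 84000 nM. The step from compound 3 to compound 4 is expected to be a 1.2-fold lower number from compound 3 to compound 4 (0.08 log units; within the scatter), within the usual scatter. Compound 4 is estimated at 70000 nM, in the range 30000 nM to 150000 nM, with a fair chance that this assay again returns only a limit.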

Compound 4, minimum cytotoxic concentration: 100000 nM
For compound 4 the middle estimate is 1.4-fold (0.15 log units) below the measured one; the measured number falls inside the stated range.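

In this assay, the change from 3-fluorobenzyl to 3,5-difluorobenzyl gives a 1.2-fold higher number from compound 3 to compound 4 (0.08 log units; within the scatter), so on this core the added fluoro leaves the read-out within the usual scatter of repeated measurements. Among these compounds, this does not show that the change carries from one core to another, as the only other fluoro-for-hydrogen step, on the core of compound 2, cannot be read, with both of its compounds returning a limit and no number: the limit of > 100000 nM in this assay, at which 2 of the 4 values shown sit A single readable step on a single core therefore gives no size to compare across cores, and it says nothing about fluoro entering at any other aromatic carbon.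

Going by these compounds, it remains open whether an amine or a nitrile on the same aromatic carbon of the 3-fluorobenzyl group would also stay within the scatter, or would give a step of readable size. On these data alone, it also remains open whether a carboxylic acid in place of the methyl ester would bring the read-out of the shared core to a number that differs from the one seen with the ester, and whether a fluoro step would then behave in the same way.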